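Swapping one ring on the most stable compound so far

The source may report more compounds than this note shows. Statements on the series, on what has been measured and on what is new or still open speak of the compounds shown alone.

Of the compounds shown here, three have been measured in an ADME assay on microsomes from liver (Mus musculus) for metabolic stability, with a stated time of 10 min; on this read-out higher numbers stand for a more stable compound and lower numbers for a less stable compound. Compound 1 `CC(=O)N1CC[C@@H](C(=O)N2CC[C@](c3ccc(C(OCc4c(F)cccc4F)(C(F)(F)F)C(F)(F)F)cc3)(S(=O)(=O)c3ccc(F)cc3)C2)C1` gives 55%, compound 2 `CC(=O)N1CCN(C(=O)N2CC[C@](c3ccc(C(OCc4c(F)cccc4C#N)(C(F)(F)F)C(F)(F)F)cc3)(S(=O)(=O)c3ccc(F)cc3)C2)CC1` gives 1%, and compound 3 `O=C(O)[C@H]1CC[C@H](C(=O)N2CC[C@](c3ccc(C(OCc4c(F)cccc4Cl)(C(F)(F)F)C(F)(F)F)cc3)(S(=O)(=O)c3ccc(F)cc3)C2)CC1` gives 87%. Compound 3 stands highest of the three, and its gaps to both others lie beyond the usual scatter. These three differ from one another in more than one place, so no measured single change is available as a guide.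

The next compound, compound 4 `O=C(O)[C@H]1CC[C@H](C(=O)N2CC[C@](c3ccc(C(OCC4CCC4)(C(F)(F)F)C(F)(F)F)cc3)(S(=O)(=O)c3ccc(F)cc3)C2)CC1`, departs from compound 3 in one place: cyclobutyl in place of 2-chloro-6-fluorophenyl on a saturated chain carbon bound to an oxygen on a saturated carbon. In words, cyclobutyl stands in place of 2-chloro-6-fluorophenyl on a saturated chain carbon bound to an oxygen on a saturated carbon.

With compound 3 at 87%, close to the top of the scale, far more room lies below than above. A fall somewhat beyond the scatter is therefore expected, estimated as a number 17 percentage points lower from compound 3 to compound 4 (beyond the scatter). For compound 4 the estimate is 70%, with an expected range of 40% to 90%.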

Compound 4, percent of the compound remaining: 39%
The estimate for compound 4 lay 31 percentage points above the measured number; the measured number lies below the stated range.
By their numbers in this assay, from the lowest: compound 2; then compound 4; then compound 1; then compound 3.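

In this assay, going by these compounds alone, this is the first change that can be read at a single place, and it is a large one: putting cyclobutyl where 2-chloro-6-fluorophenyl stood gives a number 48 percentage points lower from compound 3 to compound 4 (beyond the scatter) while the rest of the molecule stays the same. The group on a saturated chain carbon bound to an oxygen on a saturated carbon therefore matters for this read-out, even though that group lies far from the carboxylic acid end of the molecule. Nothing measured here gives a reason for the fall.

On these data alone, this one step removes the aromatic ring, the chlorine and the fluorine together, so it remains open which of these losses counts. A plain phenyl without halogens, or a cyclohexyl, at the same place would help to separate them.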